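Three Methoxy-Bearing Sulfones Stay Beyond the Assay Ceiling

A few compounds are considered here, and "the series" means these few. Any claim that something is new, unique, unknown or untested is made for them only; others in the source may bear on it.

Compound 1, `COc1ccc(CS(=O)(=O)/C=C/c2cc(OC)ccc2OC)cc1`: > 20000 nM
Compound 2, `COc1ccc(CS(=O)(=O)/C=C/c2cc(OC)cc(OC)c2)cc1`: > 20000 nM
Compound 3, `COc1ccc(CS(=O)(=O)/C=C/c2cc(OC)c(OC)cc2OC)cc1`: > 20000 nM

All three compounds were tested in a functional assay on DU-145 cells (Homo sapiens) for antiproliferative activity, read by trypan blue exclusion; on this read-out higher numbers stand for weaker inhibition and lower numbers for stronger inhibition. Compound 1 gives only > 20000 nM, which is a limit of the assay and not a number. Compound 2 likewise gives only the limit > 20000 nM. Compound 3 also stops at the limit > 20000 nM.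

Compound 3 arises from compound 1 by methoxy in place of hydrogen on an aromatic carbon. The step that the two limits leave unreadable from compound 1 to compound 3 cannot be read because of the limit of > 20000 nM in this assay, at which 3 of the 3 values shown sit. Compound 1 and compound 2 contain the same atoms joined differently; the difference between the two cores is not broken down here.

Compound 4, `COc1ccc(CS(=O)(=O)/C=C/c2cc(OC)c(OC)c(OC)c2)cc1`, has not yet been measured in this assay. It arises from compound 2 by methoxy in place of hydrogen on an aromatic carbon. Within the data shown here, this is the same kind of change as the one from compound 1 to compound 3, but the surroundings differ: in compound 3 the entering methoxy is ortho to a methoxy group and meta to a methoxy group, whereas in compound 4 it is ortho to two methoxy groups; in both it is para to a large group.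

The expected step of a number no higher from compound 2 to compound 4 (the limit leaves the size open) is small. Compound 4 is expected to land near 20000 nM, in a range from 5000 nM to 60000 nM, because the three measured compounds all sit at the limit of > 20000 nM in this assay, at which 3 of the 3 values shown sit.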

Compound 4, half-maximal inhibitory concentration: > 20000 nM
Compound 4 was reported as a limit; the forecaster's own chance of this, stated with the estimate: 75%; the middle value sits exactly at the limit.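

Compound 4 gives > 20000 nM in this assay and this is a limit of the assay, not a number. The step from compound 2 to compound 4 cannot be read, because neither compound has a number to compare: the limit of > 20000 nM in this assay, at which 4 of the 4 values shown sit.

The compounds shown leave open how strongly compound 1, compound 2, compound 3 and compound 4 inhibit these cells, and whether an added methoxy changes that at all.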